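The source may hold more compounds than are shown below. What is called first, only, known or untested is meant among the compounds shown, and "the series" means these compounds.

Measured in a functional assay on FM3A cells (Mus musculus) for cytotoxicity; a higher number here means that more compound is needed for the effect, a lower number that less compound is needed:
Compound 1 `COOC1(OOCCCc2ccccc2)CCCCCCCCCCC1`: 34000 nM
Compound 2 `COOC1(OOCCCCCCI)CCCCCCCCCCC1`: 86000 nM
Compound 3 `COOC1(OOCCCCCC(=O)O)CCCCCCCCCCC1`: 14000 nM

Compound 2 stands highest of these three numbers, and compound 1 lies nearest to it. Compound 4 `COOC1(OC)CCCCCCCCCCC1` has not yet been measured. Its structure departs from compound 2 by methyl in place of (6-iodohexyl)oxy on an oxygen on a saturated carbon, which is methyl in place of (6-iodohexyl)oxy on an oxygen on a saturated carbon. Going by the values given here, no measured step makes this change. The closest evidence comes from swaps within that chain, and these were modest: a 2.5-fold higher number from compound 1 to compound 2 (0.40 log units; beyond the scatter), a 6.1-fold lower number from compound 2 to compound 3 (0.79 log units; beyond the scatter) and a 2.4-fold lower number from compound 1 to compound 3 (0.39 log units; beyond the scatter). With compound 2 at the top of the series, a modest move to a lower number is expected in this assay, though the direction is uncertain. The expected size is a 2.2-fold lower number from compound 2 to compound 4 (0.33 log units; beyond the scatter). For compound 4 the estimate is 40000 nM, with a range of 10000 nM to 150000 nM.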

Compound 4, half-maximal effective concentration: 19000 nM
Compound 4: middle estimate off by 2.1-fold (0.32 log units), on the high side; measured number inside the range.
By their numbers in this assay, from the lowest: compounds 3, 4 and 1 (each within the scatter of the next, the first and the last beyond it); then compound 2.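

In this assay, the full replacement of (6-iodohexyl)oxy by methyl gives a 4.5-fold lower number from compound 2 to compound 4 (0.66 log units; beyond the scatter). Earlier steps only swapped groups along the chain, whereas this one shows that the effect persists without the long iodinated chain, with only methyl on this oxygen on a saturated carbon. Nothing given here accounts for the size of this step.

The compounds shown leave open how a shorter chain, such as ethoxy, would compare with methyl. They also leave open what a hexyloxy chain ending in an amine would give.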